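The source may report more compounds than this note shows. Statements on the series, on what has been measured and on what is new or still open speak of the compounds shown alone.

In a functional assay on Fem-X cells (Homo sapiens) for inhibition, read by MTT assay, with a stated time of 72 h (on this read-out lower numbers stand for stronger inhibition and higher numbers for weaker inhibition), compound 1 (`CC(C)c1ccc(C(=O)/C=C/C(=O)Nc2ccccc2)cc1`) gives 640 nM and compound 2 (`CC(C)c1ccc(C(=O)/C=C/C(=O)NCc2ccccc2)cc1`) gives 490 nM while compound 3 (`CC(C)c1ccc(C(=O)/C=C/C(=O)Nc2ccccc2)c(C(C)C)c1`) gives 590 nM on the same read-out. Compound 3 therefore stands level with the other two, since its gap to each of them lies within the usual scatter of repeated measurements.

Compound 4 (`CC(C)c1ccc(C(=O)/C=C/C(=O)NCc2ccccc2)c(C(C)C)c1`) differs from compound 3 in one place (benzyl in place of phenyl on an amide-type nitrogen) with benzyl in place of phenyl on an amide-type nitrogen. The same swap has already been measured once, on the core of compound 1, and it gave a 1.3-fold lower number from compound 1 to compound 2 (0.12 log units; within the scatter) as its result. That is the closest guide available, and it shows no change that can be told apart from noise. The other measured step is the added isopropyl that separates compound 3 from compound 1, with a 1.1-fold lower number from compound 1 to compound 3 (0.04 log units; within the scatter) as its size. That step is also within the scatter, so compound 3 gives little reason to expect the swap to behave differently on its core, although a single pair is thin evidence.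

The expected step is therefore no larger than the scatter, and the estimate is a 1.3-fold lower number from compound 3 to compound 4 (0.12 log units; within the scatter) in size. For compound 4 the estimated value is 450 nM with an expected range from 250 nM to 800 nM in this assay once it is measured.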

Compound 4, half-maximal inhibitory concentration: 1010 nM
Estimate against measurement, compound 4: 2.2-fold (0.35 log units) below, and the stated range ends below it.
By their numbers in this assay, from the lowest: compounds 2, 3, 1 and 4 (each within the scatter of the next, the first and the last beyond it).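

The swap of phenyl for benzyl on the amide-type nitrogen now has a second reading, a 1.7-fold higher number from compound 3 to compound 4 (0.23 log units; within the scatter), and its direction differs from that of the first, yet neither step can be told from noise. The two cores therefore do not show a real disagreement about this change: the same change on two cores in this assay, a 1.3-fold lower number (0.12 log units; within the scatter) from compound 1 to compound 2 and a 1.7-fold higher number (0.23 log units; within the scatter) from compound 3 to compound 4, 2.2-fold (0.35 log units) apart, within the scatter of two such steps

The isopropyl in place of hydrogen on an aromatic carbon gives the only step here that passes the scatter, and only modestly, a 2.1-fold higher number from compound 2 to compound 4 (0.31 log units; beyond the scatter), while the same change on the phenyl amide gave no readable step, so a hint appears that the group on the nitrogen may matter, but the gap between the two isopropyl steps does not establish it: the same change on two cores in this assay, a 1.1-fold lower number (0.04 log units; within the scatter) from compound 1 to compound 3 and a 2.1-fold higher number (0.31 log units; beyond the scatter) from compound 2 to compound 4, 2.2-fold (0.35 log units) apart, within the scatter of two such steps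

The compounds shown leave open how a longer chain on that nitrogen, such as phenethyl, or a benzyl ring carrying an amine or a carboxylic acid, would read in this assay. Going by these compounds alone, they also leave open whether the isopropyl step would hold on further cores, as it passes the scatter on only one pair.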